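Notes on compound 4, a fluoro variant of compound 1

The compounds below may be only part of what the source reports. "The series", "measured", "known", "first", "only" and "open" are said of these compounds alone.

The series keeps the core of compound 1 `O=C(/C=C/c1ccc2c(c1)B(O)OC2)c1ccccc1` and varies the phenyl on the carbonyl. In an ADME assay on L929 cells (Mus musculus) for cytotoxicity, read by resazurin assay, with a stated time of 72 h (on this read-out lower numbers stand for stronger inhibition and higher numbers for weaker inhibition), compound 1 gives only a limit of the assay, > 10 ug/mL. Compound 2 `COc1ccccc1C(=O)/C=C/c1ccc2c(c1)B(O)OC2`, carrying a methoxy, gives a number in this assay, 6.35 ug/mL, and the step is an at least 1.5-fold lower number from compound 1 to compound 2 (0.19 log units; that floor lies within the scatter). Compound 3 `O=C(O)c1ccc(C(=O)/C=C/c2ccc3c(c2)B(O)OC3)cc1`, carrying a carboxy, returns only a limit in this assay, > 10 ug/mL. The step that the two limits leave unreadable from compound 1 to compound 3. Two of the three values shown sit at the limit of > 10 ug/mL in this assay, at which 2 of the 3 values shown sit.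

The unmeasured compound 4 `O=C(/C=C/c1ccc2c(c1)B(O)OC2)c1cccc(F)c1` differs from compound 1 as follows: fluoro in place of hydrogen on an aromatic carbon. Neither measured step concerns a fluoro; the methoxy step is the only readable one, and its floor lies within the scatter. With compound 1 itself at a limit, the step expected for compound 4 is a step that the limit leaves unreadable from compound 1 to compound 4, nothing beyond the scatter. Compound 4 is therefore estimated at 12 ug/mL in this assay, within a range from 5 ug/mL to 30 ug/mL, and a further limit rather than a number is a real possibility.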

Compound 4, half-maximal inhibitory concentration: > 10 ug/mL
Compound 4 ended at the assay's limit (the forecaster's own chance of this, stated with the estimate: 60%); the middle value is on the limit's open side.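

Compound 4 returns only a limit in this assay, > 10 ug/mL, as compound 1 does, and no step can be read between the two. The compounds shown leave open whether 3-fluorophenyl in place of phenyl shifts the value at all, with most of the series at one limit: the limit of > 10 ug/mL in this assay, at which 3 of the 4 values shown sit.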